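Compound 3 alongside two limit values

The source may hold more compounds than are shown below. What is called first, only, known or untested is meant among the compounds shown, and "the series" means these compounds.

Compound 1 (`COc1cc2nccc(Oc3ccc4c(NC(=O)c5cccc(C(F)(F)F)c5)nn(C)c4c3)c2cc1OC`) gives > 1000 nM in a functional assay on HUVEC cells (Homo sapiens) for inhibition, with stated times of 2 h and 72 h (on this read-out lower numbers stand for stronger inhibition and higher numbers for weaker inhibition), as a limit. Compound 2 (`COc1cccc(Nc2nn(C)c3cc(Oc4ccnc5cc(OC)c(OC)cc45)ccc23)c1`) gives > 1000 nM as a limit. Compound 2 thus stands at the limit of > 1000 nM in this assay, at which 2 of the 2 values shown sit, and has no number. Compound 3 (`COc1cc2nccc(Oc3ccc4c(NC(=O)c5cccc(C)c5)nn(C)c4c3)c2cc1OC`) carries (3-methylphenyl)carbonyl in place of 3-methoxyphenyl on a nitrogen on an aromatic ring, counted as (3-methylphenyl)carbonyl in place of 3-methoxyphenyl on a nitrogen on an aromatic ring on the shared core. Among the compounds with values here, the only measured change is a step that the two limits leave unreadable from compound 1 to compound 2 and it offers no size to carry over. The expected change is a step that the limit leaves unreadable from compound 2 to compound 3 in this assay with no firm direction, and none beyond the scatter can be foreseen. Compound 3 is estimated at 2000 nM with an expected range from 700 nM to 10000 nM and will probably be reported only as a limit again.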

Compound 3, half-maximal inhibitory concentration: > 1000 nM
Compound 3 ended at the assay's limit; the forecaster's own chance of this, stated with the estimate: 80%; the middle value lies beyond the limit too.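

Within the data shown here, no step among compound 1, compound 2 and compound 3 can be read in this assay since all three values are limits: the limit of > 1000 nM in this assay, at which 3 of the 3 values shown sit. Open remains whether these compounds differ at all in this assay and which change on the shared core would give a readable number.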